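From Hydroxy to Nitro on a Shared Core

A few compounds are considered here, and "the series" means these few. Any claim that something is new, unique, unknown or untested is made for them only; others in the source may bear on it.

In a functional assay on KB cells (Homo sapiens) for antiproliferative activity, read by MTT assay, with a stated time of 72 h (a higher number here means a weaker inhibitor, a lower number a stronger inhibitor), compound 1 (`COc1ccc(-c2ssc(=O)c2-c2cc(OC)c(OC)c(OC)c2)cc1`) gives 324 nM, and compound 2 (`COc1ccc(-c2ssc(=O)c2-c2cc(OC)c(OC)c(OC)c2)cc1O`) gives 460 nM. Among the compounds with values here, these are the only two numbers available, and they cannot be told apart, so compound 2 stands level with its single measured neighbour.

Compound 3 (`COc1ccc(-c2ssc(=O)c2-c2cc(OC)c(OC)c(OC)c2)cc1[N+](=O)[O-]`) keeps the shared core but has nitro in place of hydroxy on an aromatic carbon, ortho to a methoxy group: nitro in place of hydroxy on an aromatic carbon.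

Within the data shown here, one measured step bears on this carbon. Replacing hydrogen with hydroxy there gives a 1.4-fold higher number from compound 1 to compound 2 (0.15 log units; within the scatter), so that change left the number within the scatter. Among the measured compounds shown here, no measured compound carries a nitro group, which makes this a thin guide, and it gives no direction for the new change. A shift beyond the scatter in this assay is therefore not expected. The expected change is a 1.1-fold higher number from compound 2 to compound 3 (0.04 log units; within the scatter). For compound 3 the estimated value is 500 nM, with an expected range from 150 nM to 1600 nM.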

Compound 3, half-maximal inhibitory concentration: 22300 nM
Compound 3: the middle estimate sits 45-fold (1.65 log units) below what was measured; measured number above the stated range.
By their numbers in this assay, from the lowest: compounds 1 and 2 (each within the scatter of the next); then compound 3.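

In this assay, this carbon, ortho to a methoxy group, turns out to be far from indifferent to what it carries: nitro in place of hydroxy gives (a 48-fold higher number from compound 2 to compound 3 (1.69 log units; beyond the scatter)) and nitro in place of hydrogen gives (a 69-fold higher number from compound 1 to compound 3 (1.84 log units; beyond the scatter)), which leaves compound 3 as the weakest of the three. The earlier pair showed only that hydrogen and hydroxy on this carbon cannot be told apart (a 1.4-fold higher number from compound 1 to compound 2 (0.15 log units; within the scatter)), so it could not reveal that a change here can move the number well beyond the scatter, and among these three compounds only the nitro group does so. Nothing available to this account speaks to why the nitro group has this large an effect on the number.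

What the compounds shown leave open is whether the large rise belongs to the nitro group alone, or whether other groups on this carbon, such as an amine, a fluorine atom or a carboxylic acid, would stay level with compounds 1 and 2 or climb as compound 3 does. They also leave open whether a nitro group on a different carbon of this six-membered aromatic ring would give a step of similar size.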